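Nitro in place of chloro on a weakly active compound

The source may report more compounds than this note shows. Statements on the series, on what has been measured and on what is new or still open speak of the compounds shown alone.

Compound 2 `COc1cc(C2=NN(C(C)=O)C(c3ccc(Cl)c(Cl)c3)O2)cc(OC)c1OC` was tested in a functional assay on BGC-823 cells (Homo sapiens) for antiproliferative activity, read by MTT assay, tested at 5 uM (a lower number here means a weaker effect, a higher number a stronger effect of the compound at the concentration tested), where compound 2 gives 3.1%. Among the two measured compounds this is the lowest number; the only other compound, compound 1 `COc1cc(C2=NN(C(C)=O)C(c3c(Cl)cccc3Cl)O2)cc(OC)c1OC`, gives 15.9%, and the step of a number 12.8 percentage points lower from compound 1 to compound 2 (beyond the scatter) places compound 2 clearly beneath it. Compound 3 `COc1cc(C2=NN(C(C)=O)C(c3ccc(Cl)c([N+](=O)[O-])c3)O2)cc(OC)c1OC` has not yet been measured. It differs from compound 2 in a single place: nitro in place of chloro on an aromatic carbon. For the measured compounds named here, no measured step exchanges a chloro for a nitro, and the one step known, which moves from one dichlorophenyl to another between compound 1 and compound 2, does not bear on this exchange. With nothing to lean on, the expected step is a number 4.9 percentage points higher from compound 2 to compound 3 (within the scatter), a change within the usual scatter. Compound 3 is therefore estimated to give 8%, with a range from 0% to 25%.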

Compound 3, a percentage reported as inhibition, at one concentration (the size of the read-out at that concentration, not a potency): 0%
The estimate for compound 3 lay 8 percentage points above the measured number, within the range that was stated.
By their numbers in this assay, from the lowest: compounds 3 and 2 (each within the scatter of the next); then compound 1.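

For the compounds shown here, compound 3 is the first compound here to carry something other than chloro on this six-membered aromatic ring, and in this assay the exchange for nitro appears as a number 3.1 percentage points lower from compound 2 to compound 3 (within the scatter) so, on this carbon ortho to a chloro group, the two groups cannot be told apart at the concentration tested. The longer step of a number 15.9 percentage points lower from compound 1 to compound 3 (beyond the scatter) points the same way as a number 12.8 percentage points lower from compound 1 to compound 2 (beyond the scatter) so both compounds lacking the 2,6-dichlorophenyl group read lower than compound 1. Nothing measured here offers a reason for these numbers.

Going by these compounds, whether an amine or a carboxylic acid on this same carbon would give a clearly different reading remains open. Also open, on these data alone, is whether the nitro exchange would look the same on a more active compound.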